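Swapping a nitro group for a pyrrolidine on a short chain

This account rests on a few compounds, and the source may have more. Where it says the series, first, only, none or still open, it means among the compounds named here.

Three close relatives of one small cationic core have been examined in a physicochemical assay for lipophilicity; a lower number here means a more polar compound, a higher number a more lipophilic compound. Compound 1, `C[n+]1ccn(CCCC#N)c1/C=N/O`, carries a cyano group on a three-carbon chain; compound 2, `C[n+]1ccn(CCCCC#N)c1/C=N/O`, carries the same group on a chain one carbon longer; compound 3, `C[n+]1ccn(CC[N+](=O)[O-])c1/C=N/O`, carries a nitro group on a two-carbon chain. In this assay compound 1 gives < -3, which is a limit of the assay rather than a number. In this assay compound 2 gives -2.8. For the measured compounds named here, the only measured step, a number at least 0.20 log units higher from compound 1 to compound 2 (that floor lies within the scatter), is therefore known only as a floor. For compound 3 in this assay the record holds no result reported, so its position rests on its neighbours alone, and the main evidence is the limit of < -3 in this assay, at which 1 of the 3 values shown sits, which shows that values in this series can sit at the edge of what the assay can report.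

Compound 4, `C[n+]1ccn(CCN2CCCC2)c1/C=N/O`, differs from compound 3 by pyrrolidin-1-yl in place of nitro on a saturated chain carbon, two bonds along the chain from an aromatic nitrogen. Going by the values given here, no measured step covers this particular change, so the expectation leans on how near the measured values already sit to the limit. Compound 4 is expected to give about -3 in this assay, within a range from -3.6 to -2.4, with a real chance that only a limit is reported.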

Compound 4, distribution coefficient: -2.73
Compound 4: the middle estimate sits 0.27 log units below what was measured, within the range that was stated.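

In this assay, compound 4 gives a measured number rather than a limit, which shows that a basic-free reading is not needed to place this change: with pyrrolidin-1-yl on a saturated chain carbon, two bonds along the chain from an aromatic nitrogen, the series can still return a value the assay can report. Set against the nitrile-bearing chain of compound 2, the result is a number 0.07 log units higher from compound 2 to compound 4 (within the scatter), so the compounds shown do not separate these two side chains, even though one carries a five-membered non-aromatic ring. The other comparison can be read only as a floor, a number at least 0.27 log units higher from compound 1 to compound 4 (that floor lies within the scatter).

The step from nitro to pyrrolidin-1-yl itself cannot be read, since compound 3 has no value to set beside compound 4, and the true size of any step starting from a limit also stays open: the limit of < -3 in this assay, at which 1 of the 4 values shown sits. Whether a six-membered piperidine or an open-chain diethylamino group on the same chain would also give a number rather than a limit is left unanswered by the compounds shown.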